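Adding a methoxy next to an unchanged para-hydroxy group

The source may hold more compounds than are shown below. What is called first, only, known or untested is meant among the compounds shown, and "the series" means these compounds.

Measured so far:
compound 1 `CC1=CC[C@H](C(C)(C)NC(=S)N/N=C/c2ccc(O)cc2)CC1` — > 100000 nM
compound 2 `CC1=CC[C@H](C(C)(C)NC(=S)N/N=C/c2ccccc2O)CC1` — 8400 nM

In a functional assay on NCI-H460 cells (Homo sapiens) for inhibition, read by sulforhodamine B assay, with a stated time of 48 h (a lower number here means a stronger inhibitor of growth, a higher number a weaker inhibitor of growth), compound 1 gives > 100000 nM, which is a limit of the assay and not a number (the limit of > 100000 nM in this assay, at which 1 of the 2 values shown sits). Compound 2 reaches 8400 nM, so an at least 11-fold lower number from compound 1 to compound 2 (1.07 log units; beyond the scatter). Compound 3 `COc1cc(/C=N/NC(=S)NC(C)(C)[C@H]2CC=C(C)CC2)ccc1O` differs from compound 1 by methoxy in place of hydrogen on an aromatic carbon. Among the compounds with values here, the only measured step alters the hydroxy position, not this site, so it does not bear directly on the change; no shift beyond the scatter is expected, and the result may again be a limit. Compound 3 is estimated at 90000 nM (range 25000 nM to 300000 nM), meaning an expected at least 1.1-fold lower number from compound 1 to compound 3 (0.04 log units; that floor lies within the scatter).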

Compound 3, concentration for total growth inhibition: > 100000 nM
Compound 3 ended at the assay's limit; the forecaster's own chance of this, stated with the estimate: 60%; middle value at least 1.1-fold (0.04 log units) away from the limit.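

Within the data shown here, compound 1 and compound 3 both sit at a limit of the assay, not at a number, so no step between them can be read: the limit of > 100000 nM in this assay, at which 2 of the 3 values shown sit. As far as these compounds go, whether methoxy in place of hydrogen changes anything in this assay stays open.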